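Aryl exchange from compound 2 to compound 3

The source may hold more compounds than are shown below. What is called first, only, known or untested is meant among the compounds shown, and "the series" means these compounds.

Measured compounds:
- Compound 1 `CCOc1ccc(-c2cc(=O)c3c(o2)C(CC)(CC)C(=O)C(CC)=C3O)cc1`: > 52.4 uM (a limit, not a number)
- Compound 2 `CCC1=C(O)c2c(oc(-c3cc(C)c(C)cc3C)cc2=O)C(CC)(CC)C1=O`: 8.2 uM

Within the data shown here, in a functional assay on KB cells (Homo sapiens) for antiproliferative activity, read by sulforhodamine B assay, with a stated time of 3 days (a lower number here means that less compound is needed, a higher number that more compound is needed for the effect), compound 2 gives 8.2 uM, the only actual number so far. Compound 3 `CCC1=C(O)c2c(oc(-c3ccc(OC)cc3C)cc2=O)C(CC)(CC)C1=O` is not yet measured. It carries 4-methoxy-2-methylphenyl in place of 2,4,5-trimethylphenyl on an aromatic carbon, next to the ring oxygen.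

Among the measured compounds shown here, one measured step bears on this change, as it concerns the same aromatic carbon: an at least 6.3-fold lower number from compound 1 to compound 2 (0.80 log units; beyond the scatter). Going by these compounds, this step starts from a limit, so its full size stays open, as the limit of > 52.4 uM in this assay, at which 1 of the 2 values shown sits, shows. The entering group keeps a methyl group, as in compound 2, and has an alkoxy group, as does the 4-ethoxyphenyl of compound 1. With a single step to go on, compound 3 is expected to fall between these two compounds, closer to compound 2. A small move towards a higher number is therefore expected in this assay, an estimated 2.2-fold higher number from compound 2 to compound 3 (0.34 log units; beyond the scatter). For compound 3 the expected value is 18 uM, with an estimated range of 6 uM to 50 uM.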

Compound 3, concentration for half-maximal effect: 20.9 uM
Estimate against measurement, compound 3: 1.2-fold (0.06 log units) below, within the range that was stated.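

At this aromatic carbon next to the ring oxygen, this assay now gives a step between two actual numbers: a 2.5-fold higher number from compound 2 to compound 3 (0.41 log units; beyond the scatter). The 2,4,5-trimethylphenyl and 4-methoxy-2-methylphenyl groups have the same count of heavy atoms, yet the exchange moves the read-out beyond the scatter, so the position responds to a change of the aryl substituents and not only to the larger difference seen with compound 1. Going by these compounds, compound 3 also separates two aryl groups that both carry an alkoxy group, with an at least 2.5-fold lower number from compound 1 to compound 3 (0.39 log units; beyond the scatter), but the full size of that step stays open, since it starts from a limit: the limit of > 52.4 uM in this assay, at which 1 of the 3 values shown sits.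

The exchange replaces the whole aryl group, and the compounds shown do not separate the contribution of the methoxy group from that of the lost methyl groups. Also open, on these data alone, is how an aryl group bearing an amine or a carboxylic acid, or a longer alkoxy chain together with the 2-methyl group of compound 3, would read in this assay.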